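This account rests on a few compounds, and the source may have more. Where it says the series, first, only, none or still open, it means among the compounds named here.

Of the compounds shown here, two have so far been measured in a functional assay on cells for positive allosteric modulation of metabotropic glutamate receptor 2 (Homo sapiens), read by fluorescence and calcium flux, with a stated time of 30 min; a higher number here means that more compound is needed for the effect, a lower number that less compound is needed. Compound 1, `Fc1cc(Cl)ccc1-c1ccc(Cn2nnc3ccccc32)cc1`, gives 28 nM in this assay. Compound 2, `Brc1cccc2c1nnn2CC1CCC1`, gives 20 nM in this assay. These two numbers sit within the usual scatter of each other, so neither compound can be told apart from the other on potency; compound 2 simply carries the lower of the two numbers shown. Compound 3, `CCn1nnc2c(Br)cccc21`, has not yet been measured. It differs from compound 2 in a single place: methyl in place of cyclobutyl on a saturated chain carbon bound to an aromatic nitrogen. Going by the values given here, no measured pair shows what this kind of change does, so only the change itself can guide an expectation. The step of a 4.0-fold higher number from compound 2 to compound 3 (0.60 log units; beyond the scatter) is expected to point toward a higher number, possibly reaching beyond the scatter but not by a large margin. The estimate for compound 3 in this assay is 80 nM, with a range from 20 nM to 320 nM.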

Compound 3, half-maximal effective concentration: 2240 nM
Compound 3: the middle estimate sits 28-fold (1.45 log units) below what was measured; measured number above the stated range.
By their numbers in this assay, from the lowest: compounds 2 and 1 (each within the scatter of the next); then compound 3.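

In this assay, putting methyl in place of cyclobutyl gives a 110-fold higher number from compound 2 to compound 3 (2.05 log units; beyond the scatter), so the group on a saturated chain carbon bound to an aromatic nitrogen is far from a neutral detail: with the rest of the molecule unchanged, this one place can move the number a long way. Going by these compounds alone, compounds 1 and 2 differ in more than one place and could not show this, whereas here the only changes are the loss of a four-membered carbon ring and a drop from 4 heavy atoms to 1, with no hydrogen-bond donor, acceptor or net charge on either group. No measurement at hand explains why the step is so large.

From the compounds shown here alone, it remains open whether the ring itself matters or only the carbon count, which a straight butyl chain in this place would help to separate. Going by these compounds, how a group with other atoms, such as an amine, would fare here is also open.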